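The compounds below may be only part of what the source reports. "The series", "measured", "known", "first", "only" and "open" are said of these compounds alone.

The series shares the core of compound 1 `Nc1ccccc1NC(=O)c1ccc(CSC(=S)N2CCc3ccccc32)cc1` and varies the amine attached to the thiocarbonyl carbon. In a functional assay on HeLa cells (Homo sapiens) for antiproliferative activity, read by CCK-8 assay, with a stated time of 72 h, tested at 2 uM (a higher number here means a stronger effect of the compound at the concentration tested, a lower number a weaker effect), compound 1 gives 38%, the second highest of the three numbers. Compound 2 `Nc1ccccc1NC(=O)c1ccc(CSC(=S)N2CCN(c3ccccc3F)CC2)cc1` gives 17.5% in this assay, and compound 3 `Nc1ccccc1NC(=O)c1ccc(CSC(=S)N2CCN(c3ccncc3)CC2)cc1` gives 77% in this assay. Within the data shown here, the only step between neighbours is a number 59.5 percentage points higher from compound 2 to compound 3 (beyond the scatter), a large rise that comes with a pyridine ring entering where a 2-fluorophenyl stood. Compound 4 `CN(Cc1cccnc1)C(=S)SCc1ccc(C(=O)Nc2ccccc2N)cc1` differs from compound 1 by methyl((pyridin-3-yl)methyl)amino in place of 2,3-dihydro-1H-indol-1-yl on a thiocarbonyl carbon. Among the measured compounds shown here, this change also brings a pyridine ring onto the amine, and the step from compound 2 to compound 3 is the only measured step that bears on it, so a rise is expected, though the amine here is open rather than part of a ring and the pyridine is attached through a methylene, which no measured pair covers. Compound 4 is therefore expected to show a number 17 percentage points higher from compound 1 to compound 4 (beyond the scatter). The estimate for compound 4 is 55%, with a likely range from 30% to 80%.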

Compound 4, a percentage reported as inhibition, at one concentration (the size of the read-out at that concentration, not a potency): 16.4%
For compound 4 the middle estimate is 38.6 percentage points above the measured one; measured number below the stated range.
By their numbers in this assay, from the lowest: compounds 4 and 2 (each within the scatter of the next); then compound 1; then compound 3.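

Bringing a pyridine ring onto the thiocarbonyl carbon does not by itself raise the reading in this assay: the change from 2,3-dihydro-1H-indol-1-yl to methyl((pyridin-3-yl)methyl)amino gives a number 21.6 percentage points lower from compound 1 to compound 4 (beyond the scatter). A pyridine ring entering the amine therefore goes with a rise in one step, a number 59.5 percentage points higher from compound 2 to compound 3 (beyond the scatter), and a fall in the other, so the two steps show no common direction. Nothing measured on these compounds explains the fall.

The compounds shown leave open whether the fall goes with the open amine, the methylene link or the pyridin-3-yl attachment. A benzyl(methyl)amino group or a piperidine on the same thiocarbonyl carbon would help to tell these apart.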